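Ortho-benzylamine diaryl series: dopamine transporter working notes

A few compounds are considered here, and "the series" means these few. Any claim that something is new, unique, unknown or untested is made for them only; others in the source may bear on it.

Measured compounds:
compound 1 `CNCc1ccccc1Cc1ccc(SC)cc1` — 5900 nM
compound 2 `CN(C)Cc1ccccc1Sc1ccc(Cl)cc1` — "not determined" (no result reported)
compound 3 `CN(C)Cc1ccccc1Oc1ccc(C#N)cc1` — "not determined" (no result reported)
compound 4 `CN(C)Cc1ccccc1Oc1ccc(C2CC2)cc1` — not yet measured

In an assay on HEK293 cells for inhibition of sodium-dependent dopamine transporter (Homo sapiens) (a lower number here means a stronger inhibitor, a higher number a weaker inhibitor), compound 1 gives 5900 nM. In this assay compound 2 gives "not determined" (no result reported). In this assay compound 3 gives "not determined" (no result reported), so compound 3 stands without any value of its own; the only anchor in the series is compound 1. The change from compound 3 to compound 4 is cyclopropyl in place of cyano on an aromatic carbon. Among the measured compounds shown here, no measured pair covers this exchange, so no step size is known; with compound 1 as the only reference, a modest outcome in this assay is expected, without a clear direction. Compound 4 is estimated at 3000 nM in this assay, with an expected range of 600 nM to 15000 nM.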

Compound 4, half-maximal inhibitory concentration: 4200 nM
For compound 4 the middle estimate is 1.4-fold (0.15 log units) below the measured one; the range from low to high includes it.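

Compound 3 has no value to set against compound 4, so no step can be read between them. The compounds shown leave open what cyclopropyl in place of cyano does in this assay. No evidence bears on this result.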